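Aryl variation on a shared core: compound 4

The source may report more compounds than this note shows. Statements on the series, on what has been measured and on what is new or still open speak of the compounds shown alone.

Measured so far in a functional assay on KB cells (Homo sapiens) for antiproliferative activity, read by sulforhodamine B assay, with a stated time of 3 days; a lower number here means that less compound is needed, a higher number that more compound is needed for the effect:
compound 1 `CCC1=C(O)c2c(oc(-c3ccc(Br)cc3)cc2=O)C(CC)(CC)C1=O` — in this assay compound 1 gives only a limit, > 48.1 uM.
compound 2 `CCC1=C(O)c2c(oc(-c3ccccc3OC)cc2=O)C(CC)(CC)C1=O` — compound 2 gives 40.8 uM.
compound 3 `CCC1=C(O)c2c(oc(-c3ccc(C)cc3C)cc2=O)C(CC)(CC)C1=O` — compound 3 gives 41.2 uM.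

Compound 3 stands highest of the two numbers; its nearest neighbour is compound 2, with a 1.0-fold higher number from compound 2 to compound 3 (0.00 log units; within the scatter). The value of compound 1 is a limit (the limit of > 48.1 uM in this assay, at which 1 of the 3 values shown sits), so that step is a floor only: an at least 1.1-fold lower number from compound 1 to compound 3 (0.06 log units; that floor lies within the scatter), and likewise an at least 1.1-fold lower number from compound 1 to compound 2 (0.07 log units; that floor lies within the scatter).

Compound 4 `CCC1=C(O)c2c(oc(-c3cc(C)c(O)c(C)c3)cc2=O)C(CC)(CC)C1=O` differs from compound 3 at the aryl group: 4-hydroxy-3,5-dimethylphenyl in place of 2,4-dimethylphenyl on an aromatic carbon.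

Going by the values given here, the steps that bear on this change are the aryl swaps from compound 1 to compound 3 and from compound 2 to compound 3, all within the scatter or floors that lie within it. Three aryl groups therefore give the same picture in this assay, and no step beyond the scatter is expected for compound 4 either.

Compound 4 is estimated at 38 uM, with a range of 18 uM to 80 uM. The expected step is a 1.1-fold lower number from compound 3 to compound 4 (0.04 log units; within the scatter).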

Compound 4, concentration for half-maximal effect: 18.3 uM
The estimate for compound 4 lay 2.1-fold (0.32 log units) above the measured number, within the range that was stated.
By their numbers in this assay, from the lowest: compound 4; then compounds 2 and 3 (each within the scatter of the next). At a limit, above all of these: compound 1.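

The aryl group on the carbon next to the ring oxygen can move the number in this assay beyond the scatter: 4-hydroxy-3,5-dimethylphenyl gives a 2.3-fold lower number from compound 3 to compound 4 (0.35 log units; beyond the scatter) and a 2.2-fold lower number from compound 2 to compound 4 (0.35 log units; beyond the scatter) as modest steps, where the earlier aryl swaps stayed within the scatter or gave floors within it. Against compound 1 the step reads an at least 2.6-fold lower number from compound 1 to compound 4 (0.41 log units; beyond the scatter) and remains a floor. Compound 1 gives a limit and not a number: (the limit of > 48.1 uM in this assay, at which 1 of the 4 values shown sits).

The swap adds the hydroxyl and rearranges the methyl groups at once, and the compounds shown do not tell these two changes apart. On these data alone, whether plain 4-hydroxyphenyl, or an amine or a carboxylic acid in place of the hydroxyl, would hold or extend the step stays open.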